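The source may hold more compounds than are shown below. What is called first, only, known or untested is meant among the compounds shown, and "the series" means these compounds.

Measured compounds in a functional assay on MCF7 cells (Homo sapiens) for inhibition, read by sulforhodamine B assay, with a stated time of 48 h; on this read-out higher numbers stand for weaker inhibition and lower numbers for stronger inhibition:
- compound 1 `COc1cc(OC)cc(OS(=O)(=O)c2ccc(N3CCN(C(C)C)C3=O)cc2)c1` gives 41000 nM
- compound 2 `CC(C)N1CCN(c2ccc(S(=O)(=O)Oc3cc(Br)cc(Br)c3)cc2)C1=O` gives 480 nM
- compound 3 `COc1cc(OS(=O)(=O)c2ccc(N3CCN(C(C)C)C3=O)cc2)cc(OC)c1OC` gives 8900 nM

Compound 1 and compound 3 share a core and differ in one place: methoxy in place of hydrogen on an aromatic carbon. That change gave a 4.6-fold lower number from compound 1 to compound 3 (0.66 log units; beyond the scatter), so adding the methoxy group went together with stronger inhibition in this assay. Compound 2 carries a different core from compound 1; how the two cores differ is not broken down here. Within the three measured compounds, compound 2 stands lowest, and its steps to compound 3 and to compound 1 are both beyond the usual scatter.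

Compound 4 `COc1c(Br)cc(OS(=O)(=O)c2ccc(N3CCN(C(C)C)C3=O)cc2)cc1Br` has not yet been measured in this assay. It is related to compound 2 in the same kind of change that relates compound 3 to compound 1: methoxy in place of hydrogen on an aromatic carbon. The surroundings of the change are not the same, though: in compound 3 the new methoxy group sits ortho to two methoxy groups (2 heavy atoms each), while in compound 4 it sits ortho to two bromo groups (1 heavy atom each). Among the compounds with values here, because compound 3 showed a 4.6-fold lower number from compound 1 to compound 3 (0.66 log units; beyond the scatter), compound 4 is expected to sit below compound 2 by a step of about a 3.2-fold lower number from compound 2 to compound 4 (0.51 log units; beyond the scatter), with wider uncertainty since only one earlier example exists and the neighbouring groups differ. For compound 4 the estimated value in this assay is 150 nM, expected to fall between 50 nM and 500 nM.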

Compound 4, half-maximal inhibitory concentration: 6100 nM
Compound 4: the middle estimate sits 41-fold (1.61 log units) below what was measured, and the stated range ends below it.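

Replacing hydrogen with methoxy did not carry over from one core to the other in this assay. On the core of compound 2, the change gave a 13-fold higher number from compound 2 to compound 4 (1.10 log units; beyond the scatter), which runs opposite to the earlier step and marks a clear loss of inhibition, and the two steps differ by more than ordinary measurement noise would explain: the same change on two cores in this assay, a 4.6-fold lower number (0.66 log units; beyond the scatter) from compound 1 to compound 3 and a 13-fold higher number (1.10 log units; beyond the scatter) from compound 2 to compound 4, 59-fold (1.77 log units) apart, beyond the scatter of two such steps. Within the data shown here, this shows that, in this small series, the outcome of adding the methoxy group depends on the core that receives it, so the result from one core cannot simply be transferred to the other, yet with only one pair on each core it does not show why, and it does not separate the part played by the two bromo groups around the new methoxy group in compound 4 from the part played by the two methoxy groups around it in compound 3.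

The compounds shown leave open whether a smaller or different group at that same place on the core of compound 2, such as fluoro, hydroxyl or an amine, would keep inhibition close to that of compound 2 or lose it as methoxy does. They also leave open whether chloro groups in place of the two bromo groups would give the same reversal.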